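Aryl swap at the para position of a triazine anilide series

The compounds below may be only part of what the source reports. "The series", "measured", "known", "first", "only" and "open" are said of these compounds alone.

Compound 1 `C=CC(=O)Nc1cccc(Nc2ncnc(Nc3ccc(C(=O)Nc4ccc(C)cn4)cc3)n2)c1` gives 125000 nM in a functional assay on Raji cells (Homo sapiens) for antiproliferative activity, read by CCK-8 assay, with a stated time of 24 h; on this read-out lower numbers stand for stronger inhibition and higher numbers for weaker inhibition. Compound 2 `C=CC(=O)Nc1cccc(Nc2ncnc(Nc3ccc(-c4ccc(C)nc4)cc3)n2)c1` gives 13800 nM. Compound 3 `C=CC(=O)Nc1cccc(Nc2ncnc(Nc3ccc(C(=O)N4CCCCC4)cc3)n2)c1` gives 5140 nM. Compound 4 `C=CC(=O)Nc1cccc(Nc2ncnc(Nc3ccc(-c4cccnc4)cc3)n2)c1` has not yet been measured.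

Among the three measured compounds, compound 3 stands with the lowest number, and both of its steps to the others are beyond the scatter: a 24-fold lower number from compound 1 to compound 3 (1.39 log units; beyond the scatter) and a 2.7-fold lower number from compound 2 to compound 3 (0.43 log units; beyond the scatter). The step to compound 4 replaces one group on the shared core, (pyridin-3-yl in place of (piperidin-1-yl)carbonyl on an aromatic carbon). For the measured compounds named here, the step that bears most directly on it is the one between compound 2 and compound 3, since compound 2 carries 6-methylpyridin-3-yl at the same position and compound 4 carries pyridin-3-yl; that step was a 2.7-fold lower number from compound 2 to compound 3 (0.43 log units; beyond the scatter). Reversing it points to a higher number for compound 4, and the data contain no measured pair that separates the methyl from the pyridine ring itself. The expected step is therefore a 2.3-fold higher number from compound 3 to compound 4 (0.37 log units; beyond the scatter), a modest rise in this assay. Compound 4 is estimated at 12000 nM, with a range from 4000 nM to 40000 nM.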

Compound 4, half-maximal inhibitory concentration: 12400 nM
For compound 4 the middle estimate is 1.0-fold (0.01 log units) below the measured one, and the stated range covers the measured number.
By their numbers in this assay, from the lowest: compound 3; then compounds 4 and 2 (each within the scatter of the next); then compound 1.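

For the compounds shown here, compound 4 separates the methyl from the pyridine ring for the first time: in this assay, taking off the methyl gives a 1.1-fold lower number from compound 2 to compound 4 (0.05 log units; within the scatter), so at this position the methyl on the pyridin-3-yl ring makes no difference that can be told from the scatter. The gap to the amide of piperidine therefore belongs to the unsubstituted ring as well, with a 2.4-fold higher number from compound 3 to compound 4 (0.38 log units; beyond the scatter) on this change. Set against the (5-methylpyridin-2-yl)carbamoyl group, the directly attached pyridin-3-yl ring gives a 10-fold lower number from compound 1 to compound 4 (1.00 log units; beyond the scatter), so compound 1 remains well apart from both pyridines.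

Nothing shown here explains why these groups differ. Going by these compounds, it also remains open whether a plain phenyl ring or a morpholin-4-ylcarbonyl group on this aromatic carbon would fall with compound 3 or with compound 4.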